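Swapping the benzothiazole for a pyrazine ring

A few compounds are considered here, and "the series" means these few. Any claim that something is new, unique, unknown or untested is made for them only; others in the source may bear on it.

Compound 1 `CC(C)(C)Sc1c(CC(C)(C)C(=O)O)n(Cc2ccc(Cl)cc2)c2ccc(OCc3nc4ccccc4s3)cc12` is assessed in a functional assay for inhibition, with Homo sapiens as the target (a higher number here means a weaker inhibitor, a lower number a stronger inhibitor), and gives 3 nM. Compound 2 `CC(C)(C)Sc1c(CC(C)(C)C(=O)O)n(Cc2ccc(Cl)cc2)c2ccc(OCc3cccnc3)cc12` gives 8 nM, and compound 3 `C[C@H](COc1ccc2c(c1)c(SC(C)(C)C)c(CC(C)(C)C(=O)O)n2Cc1ccc(Cl)cc1)c1ccccn1` gives 3 nM. Compound 1 thus sits level with compound 3, the two sharing the lowest numbers of the three, while compound 2 shows a 2.7-fold higher number from compound 1 to compound 2 (0.43 log units; beyond the scatter). Compound 4 `CC(C)(C)Sc1c(CC(C)(C)C(=O)O)n(Cc2ccc(Cl)cc2)c2ccc(OCc3cnccn3)cc12` has not yet been tested; its difference from compound 1 is pyrazin-2-yl in place of 1,3-benzothiazol-2-yl on a saturated chain carbon bound to an oxygen on an aromatic ring. The step that bears most on this is the move to a single six-membered ring with one nitrogen, a 2.7-fold higher number from compound 1 to compound 2 (0.43 log units; beyond the scatter); the step of no change at the digits printed from compound 1 to compound 3 (within the scatter) shows a different replacement leaving the number unchanged. A modest increase is therefore expected, a 3.0-fold higher number from compound 1 to compound 4 (0.48 log units; beyond the scatter), and compound 4 is estimated at 9 nM with a range of 4 nM to 20 nM.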

Compound 4, half-maximal inhibitory concentration: 4 nM
Compound 4: the middle estimate sits 2.3-fold (0.35 log units) above what was measured; the range from low to high includes it.
By their numbers in this assay, from the lowest: compounds 1, 3, 4 and 2 (each within the scatter of the next, the first and the last beyond it).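

On this saturated chain carbon, pyrazin-2-yl stands in place of 1,3-benzothiazol-2-yl, 6 heavy atoms for 9 and one ring for two, with a 1.3-fold higher number from compound 1 to compound 4 (0.12 log units; within the scatter). A single six-membered ring therefore need not cost anything beyond the scatter here, as compound 2 alone had suggested it might. The other two comparisons, a 1.3-fold higher number from compound 3 to compound 4 (0.12 log units; within the scatter) and a 2.0-fold lower number from compound 2 to compound 4 (0.30 log units; within the scatter), separate compound 4 from neither neighbour. No measurement here accounts for these results. Still open, as far as these compounds go, is whether a morpholine ring or a simple amine at this place would keep the number as low.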